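Working notes: dropping the 4-methoxyphenyl group from compound 2

The source may hold more compounds than are shown below. What is called first, only, known or untested is meant among the compounds shown, and "the series" means these compounds.

In a functional assay on MCF7 cells (Homo sapiens) for antiproliferative activity, read by MTT assay, with a stated time of 72 h (on this read-out higher numbers stand for weaker inhibition and lower numbers for stronger inhibition), compound 1 (`COc1ncc(-c2ccc3c(c2)NC(=O)CO3)cc1NS(=O)(=O)c1ccc(F)cc1`) gives 32300 nM while compound 2 (`COc1ccc(N2C(=O)COc3ccc(-c4cnc(Cl)c(NS(=O)(=O)c5ccc(F)cc5)c4)cc32)cc1`) gives 36000 nM so the two stand within the usual scatter of each other and no order can be drawn between them.

Compound 3 (`O=C1COc2ccc(-c3cnc(Cl)c(NS(=O)(=O)c4ccc(F)cc4)c3)cc2N1`) differs from compound 2 in one place, with hydrogen in place of 4-methoxyphenyl on an amide-type nitrogen in a ring. Among the measured compounds shown here, no measured pair yet shows a step at this nitrogen. The nearest guide is compound 1, which also has hydrogen there and gives 32300 nM although it differs from compound 3 elsewhere on the core.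

On that single comparison, no step beyond the scatter is expected in this assay with only a slight lean toward stronger inhibition. The estimated step (a 1.4-fold lower number from compound 2 to compound 3 (0.16 log units; within the scatter)) stays small against the spread of such measurements. Compound 3 is estimated at 25000 nM with 9000 nM to 55000 nM as the expected range. For the measured compounds named here, only two measured compounds support this estimate, so the range is kept wide.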

Compound 3, half-maximal inhibitory concentration: > 40000 nM
Compound 3 gave a limit, no number (the forecaster's own chance of this, stated with the estimate: 10%); at least 1.6-fold (0.20 log units) between middle value and limit.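

Notes on the result: In this assay compound 3 reads as a limit of the assay and not as a number: the limit of > 40000 nM in this assay, at which 1 of the 3 values shown sits. Among the compounds shown here, with hydrogen in place of 4-methoxyphenyl on the amide-type nitrogen in the ring, this gives the first reading at this position, an at least 1.1-fold higher number from compound 2 to compound 3 (0.04 log units; that floor lies within the scatter), so the series has only a floor for this change and no demonstrated effect of the group in either direction. With chloro in place of methoxy on an aromatic carbon, the other new pair gives an at least 1.2-fold higher number from compound 1 to compound 3 (0.09 log units; that floor lies within the scatter), again only a floor, so neither place can yet be ranked and neither change can be said to matter in this assay.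

Going by these compounds, the true size of both steps stays open, and so does whether any group on this nitrogen can bring the number clearly down from the level of compound 1 and compound 2. A methyl or a 2-aminoethyl chain on that nitrogen, or an amine in place of chloro on that aromatic carbon, would test whether either place can move the read-out beyond the scatter.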